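Notes on the step from compound 2 to compound 4

The source may hold more compounds than are shown below. What is called first, only, known or untested is meant among the compounds shown, and "the series" means these compounds.

Measured in an ADME assay on HCT-116 cells (Homo sapiens) for cytotoxicity, read by CellTiter-Glo, with a stated time of 72 h (a lower number here means a stronger inhibitor, a higher number a weaker inhibitor), each entry a limit of the assay:
- compound 1 (`Cc1cc(C)c(S(=O)(=O)N2CCN(C3CN4CCC3CC4)CC2)c(C)c1`): > 5000 nM
- compound 2 (`Cc1cc(C)c(S(=O)(=O)N2CCC(N3CCN(C)CC3)CC2)c(C)c1`): > 5000 nM
- compound 3 (`CC1CCN(C2CCN(S(=O)(=O)c3ccc(C(C)C)cc3)CC2)CC1`): > 5000 nM

Compound 2 has no numerical value, only the limit > 5000 nM. It stands with the rest of the set: the limit of > 5000 nM in this assay, at which 3 of the 3 values shown sit. Among the compounds with values here, no measured pair offers a numerical step to work from.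

Compound 4 (`Cc1cc(C)c(S(=O)(=O)N2CCC(C(=O)N3CCC(C)CC3)CC2)c(C)c1`) differs from compound 2 in one place: (4-methylpiperidin-1-yl)carbonyl in place of 4-methylpiperazin-1-yl on a saturated ring carbon. In words, this is (4-methylpiperidin-1-yl)carbonyl in place of 4-methylpiperazin-1-yl on a saturated ring carbon.

In this assay the expected step is a number no higher from compound 2 to compound 4 (the limit leaves the size open), which means no expected change beyond the scatter and no expected direction. This expectation rests on compound 2 with its limit > 5000 nM, and another limit is the likeliest report. For compound 4 the estimated value is 5000 nM, with an expected range from 2500 nM to 10000 nM.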

Compound 4, half-maximal inhibitory concentration: > 5000 nM
Compound 4: a limit, no number; the forecaster's own chance of this, stated with the estimate: 85%; the middle value lies on the limit itself.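

Compound 2 and compound 4 are both reported only as limits in this assay, so no step can be read between them. The compounds shown leave open which change to the shared core, if any, would give a numerical value, as the whole set stands at: the limit of > 5000 nM in this assay, at which 4 of the 4 values shown sit.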